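The source may hold more compounds than are shown below. What is called first, only, known or untested is meant among the compounds shown, and "the series" means these compounds.

Compound 1 `C=CCn1cc(C(=O)OCC)c(=O)c2ccc(Cl)cc21` is the starting point. Among the measured compounds shown here, in a functional assay on MCF7 cells (Homo sapiens) for cytotoxicity, read by MTT assay, with a stated time of 24 h (on this read-out higher numbers stand for weaker inhibition and lower numbers for stronger inhibition), compound 1 gives 49800 nM, the only outright number in this small set. Compound 2 `CCOC(=O)c1cn(CC)c2cc(Cl)ccc2c1=O` differs from compound 1 by a methyl in place of vinyl on a saturated chain carbon bound to an aromatic nitrogen. In this assay compound 2 reaches only a limit, > 50000 nM. On these data alone, that comparison gives a number no lower from compound 1 to compound 2 (the limit leaves the size open), and its size stays open because of the limit of > 50000 nM in this assay, at which 1 of the 2 values shown sits.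

Compound 3 `CCOC(=O)c1cn(CCCc2ccccc2)c2cc(Cl)ccc2c1=O` has not yet been measured. It differs from compound 1 as follows: phenethyl in place of vinyl on a saturated chain carbon bound to an aromatic nitrogen. For the measured compounds named here, the one measured step, from compound 1 to compound 2, bears only loosely on this change: it swapped the vinyl for a methyl rather than a phenethyl, showed no gain, and its size cannot be read. With so little to go on, no shift beyond the usual scatter is expected in this assay, in either direction. Compound 3 is estimated at 50000 nM, within 20000 nM to 120000 nM. The expected step is a 1.0-fold higher number from compound 1 to compound 3 (0.00 log units; within the scatter), which is meant to lie within the scatter.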

Compound 3, half-maximal inhibitory concentration: 14100 nM
The estimate for compound 3 lay 3.5-fold (0.55 log units) above the measured number, outside the stated range (below it).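

In this assay, among the compounds shown here, phenethyl in place of vinyl on a saturated chain carbon bound to an aromatic nitrogen gives a 3.5-fold lower number from compound 1 to compound 3 (0.55 log units; beyond the scatter), the first change at this position whose size can be read and the first shift beyond the scatter. Adding benzyl in place of hydrogen on the saturated chain carbon, two bonds along the chain from an aromatic nitrogen, gives an at least 3.5-fold lower number from compound 2 to compound 3 (0.54 log units; beyond the scatter), so among these three compounds the one with the six-membered aromatic ring on the chain has the lowest number. Compound 2 gives > 50000 nM as a limit and not a number, so the second step fixes only a lower bound on the size of the change, and the reason lies here: the limit of > 50000 nM in this assay, at which 1 of the 3 values shown sits.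

Compound 3 changes the chain length and adds the aromatic ring together, so the compounds shown do not tell which of the two goes with the lower number. A hexyl chain with no ring, or an amine in place of the phenyl ring, would pull those two apart.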